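This account rests on a few compounds, and the source may have more. Where it says the series, first, only, none or still open, it means among the compounds named here.

In a functional assay on PC-3 cells (Homo sapiens) for inhibition, read by sulforhodamine B assay, with a stated time of 48 h, tested at 50 uM (on this read-out lower numbers stand for less inhibition of growth and higher numbers for more inhibition of growth at the one concentration tested), compound 1 `COc1ccc([C@@H]2C/C(=N/OCc3cn(-c4ccc(O)cc4)nn3)c3cc(CC=C(C)C)c(OC)cc3O2)cc1` gives 64% and compound 2 `COc1cc2c(cc1CC=C(C)C)/C(=N/NC(N)=O)C[C@@H](c1ccc(O)cc1)O2` gives 67%, so these two values lie within the scatter of each other. Compound 3 `COc1ccc([C@@H]2C/C(=N/OCc3cn(-c4cc(OC)c(OC)c(OC)c4)nn3)c3cc(CC=C(C)C)c(OC)cc3O2)cc1` differs from compound 1 in one place: 3,4,5-trimethoxyphenyl in place of 4-hydroxyphenyl on an aromatic nitrogen, with 3,4,5-trimethoxyphenyl in place of 4-hydroxyphenyl on an aromatic nitrogen. For the measured compounds named here, no measured pair shows a change of this kind. In this assay no step beyond the scatter is therefore expected, in either direction. The expected step is a number 2 percentage points higher from compound 1 to compound 3 (within the scatter). The estimate for compound 3 is 66%, within an expected range of 50% to 82%.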

Compound 3, percent growth inhibition at one concentration: 36%
Compound 3: the middle estimate sits 30 percentage points above what was measured, and the stated range ends above it.
By their numbers in this assay, from the lowest: compound 3; then compounds 1 and 2 (each within the scatter of the next).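

In this assay, for the compounds shown here, the aromatic nitrogen substituent proves sensitive to change: 3,4,5-trimethoxyphenyl in place of 4-hydroxyphenyl gives a number 28 percentage points lower from compound 1 to compound 3 (beyond the scatter) and is the first step to read beyond the scatter. Growth inhibition at this one concentration therefore depends on the aryl group at this place. Nothing shown here bears on the reason for this step.

The change alters the hydroxyl and the methoxy groups together, so their separate contributions remain unresolved. Going by these compounds, whether a plain phenyl, a 4-methoxyphenyl or a 4-aminophenyl would keep the level of compound 1 remains open.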